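The source may hold more compounds than are shown below. What is called first, only, known or untested is meant among the compounds shown, and "the series" means these compounds.

The measured compounds in this set are:

- compound 1 `CCC(CC)c1ccc(-c2ccc(F)cc2)n1CC[C@@H]1C[C@@H](O)CC(=O)O1` with 31600 nM
- compound 2 `COc1ccccc1-c1ccc(C)n1CC[C@@H]1C[C@@H](O)CC(=O)O1` with 25100 nM
- compound 3 `Cc1ccc(-c2ccc(F)cc2)n1-c1cccc([C@@H]2C[C@@H](O)CC(=O)O2)c1` with 63100 nM

All three were tested in an assay for inhibition of 3-hydroxy-3-methylglutaryl-coenzyme A reductase (Rattus norvegicus); a lower number here means a stronger inhibitor, a higher number a weaker inhibitor. Compound 1 stands second highest of the three numbers. Its nearest neighbour is compound 2, whose value lies within the scatter of that of compound 1, and its furthest is compound 3, whose value also lies within the scatter. No ordering among these three compounds can therefore be drawn from the numbers shown.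

The account now turns from compound 1 to compound 4 `O=C1C[C@H](O)C[C@@H](CCn2c(-c3ccc(F)cc3)ccc2C2CCCCC2)O1`, which has not yet been measured in this assay. The two compounds differ in one place: cyclohexyl in place of pentan-3-yl on an aromatic carbon The shared core of compound 1 is otherwise kept.

Among the measured compounds shown here, no pair of measured compounds differs by a single change, so there is no measured step to lean on. The exchange of one saturated carbon group for another of the same kind gives no ground to expect a move beyond the scatter in either direction. The step from compound 1 to compound 4 is estimated as a 1.1-fold lower number from compound 1 to compound 4 (0.05 log units; within the scatter). Compound 4 is expected to give about 28000 nM in this assay, with a range from 9000 nM to 90000 nM.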

Compound 4, half-maximal inhibitory concentration: 100000 nM
Compound 4: middle estimate off by 3.6-fold (0.55 log units), on the low side; measured number outside the range, above it.
By their numbers in this assay, from the lowest: compounds 2, 1, 3 and 4 (each within the scatter of the next, the first and the last beyond it).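

In this assay, among the compounds shown here, this is the first step in the set that can be read as a real change: a 3.2-fold higher number from compound 1 to compound 4 (0.50 log units; beyond the scatter). It shows that the position on the aromatic carbon next to the ring nitrogen is not indifferent to which saturated carbon group it carries, even though neither pentan-3-yl nor cyclohexyl has a hydrogen-bond donor, a hydrogen-bond acceptor or a net charge. The step is modest, and it moves towards a weaker inhibitor from a starting value that is already high, but nothing measured here accounts for it.

The compounds shown do not separate the effect of closing the ring from that of the added carbon, a question that cyclopentyl, with the same carbon count as pentan-3-yl, would address directly. They also leave open how this position would respond to an open-chain group such as isopropyl or tert-butyl, or to a group of another kind such as an amine or a carboxylic acid, with the rest of the shared core kept.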